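This account rests on a few compounds, and the source may have more. Where it says the series, first, only, none or still open, it means among the compounds named here.

Compound 1 `Cc1cc(Nc2cc(N3CCN(C)CC3)nc(Nc3ccc([N+](=O)[O-])cc3)n2)n[nH]1` and compound 2 `Cc1cc(Nc2cc(N3CCN(C)CC3)nc(Nc3ccc(C#N)cc3)n2)n[nH]1` share one core and differ in a single group on an aromatic carbon. Going by the values given here, in a functional assay on U-937 cells (Homo sapiens) for antiproliferative activity, read by CCK-8 assay, with a stated time of 72 h (a higher number here means a weaker inhibitor, a lower number a stronger inhibitor), compound 1 gives 43.3 nM, the highest of the two numbers known; compound 2 gives 9.03 nM. Among the compounds with values here, the one measured step, a 4.8-fold lower number from compound 1 to compound 2 (0.68 log units; beyond the scatter), is cyano in place of nitro on an aromatic carbon. Compound 3 `COc1ccc(Nc2nc(Nc3cc(C)[nH]n3)cc(N3CCN(C)CC3)n2)cc1` has not yet been measured; it differs from compound 1 by methoxy in place of nitro on an aromatic carbon. Within the data shown here, the only measured step that bears on it is the one already described: it too removes nitro from that carbon. Methoxy, however, appears in no measured compound, so that step shows only that removing nitro here can lower the number. A modest downward step, or none beyond the scatter, is therefore expected, as a 1.7-fold lower number from compound 1 to compound 3 (0.24 log units; within the scatter). Compound 3 is estimated at 25 nM, within a range from 8 nM to 80 nM.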

Compound 3, half-maximal inhibitory concentration: 92.3 nM
Beside the measured number, compound 3's estimate is 3.7-fold (0.57 log units) below it; measured number outside the range, above it.
By their numbers in this assay, from the lowest: compound 2; then compound 1; then compound 3.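

Taking nitro off this carbon does not by itself lower the number in this assay: methoxy in its place gives a 2.1-fold higher number from compound 1 to compound 3 (0.33 log units; beyond the scatter), the opposite direction to the cyano step, so the outcome depends on which group enters. The gap between the two replacements is wider still, at a 10-fold higher number from compound 2 to compound 3 (1.01 log units; beyond the scatter), which shows that this para position separates the three groups clearly, with cyano giving the lowest number and methoxy the highest. Nothing given here accounts for this order.

The compounds shown leave open how an amine, a carboxylic acid or a chlorine atom would fare on this carbon, and whether a longer chain in place of methoxy would raise the number further. They also leave open whether the same order of cyano, nitro and methoxy holds on another core.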